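This account rests on a few compounds, and the source may have more. Where it says the series, first, only, none or still open, it means among the compounds named here.

In a physicochemical assay for lipophilicity, at pH 7.4 (on this read-out higher numbers stand for higher lipophilicity and lower numbers for lower lipophilicity), two compounds built on one shared core have been measured so far. Compound 1 `CNC(=O)c1cc(C(=O)NC2CC2)cn(Cc2cccc3[nH]ccc23)c1=O` gives 2.9, and compound 2 `CNC(=O)c1cc(C(=O)NC2CC2)cn(CC2CCCOC2)c1=O` gives 2, the lower of the two numbers. Among the measured compounds shown here, the only measured step is a number 0.90 log units lower from compound 1 to compound 2 (beyond the scatter), and it comes with oxan-3-yl in place of 1H-indol-4-yl on a saturated chain carbon bound to an aromatic nitrogen. Compound 3 `CNC(=O)c1cc(C(=O)NC2CC2)cn(CC2CCOCC2)c1=O` differs from compound 2 at that same place: oxan-4-yl in place of oxan-3-yl on a saturated chain carbon bound to an aromatic nitrogen. Here oxan-4-yl stands in place of oxan-3-yl, so the two compounds have the same atoms, joined differently. The earlier step exchanged two quite different groups, whereas the counted features on both sides of this change are the same. For the measured compounds named here, no measured pair compares these two groups directly, so the evidence is indirect. The step of compound 2 from compound 1, a number 0.90 log units lower from compound 1 to compound 2 (beyond the scatter), therefore serves only as an upper guide, and a much smaller change is expected here. The expected change is no change at the digits printed from compound 2 to compound 3 (within the scatter), which would lie within the scatter. Compound 3 is estimated at 2, with an expected range from 1.6 to 2.4.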

Compound 3, distribution coefficient: 1.5
Compound 3: the middle estimate sits 0.50 log units above what was measured; the whole stated range lies above it.
By their numbers in this assay, from the lowest: compound 3; then compound 2; then compound 1.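

In this assay, oxan-4-yl in place of oxan-3-yl on a saturated chain carbon bound to an aromatic nitrogen comes with a number 0.50 log units lower from compound 2 to compound 3 (beyond the scatter), so this place in the shared core separates two groups that have the same atoms, the same ring size and the same hydrogen-bond counts. The earlier pair tied a lower number only to the exchange of 1H-indol-4-yl for oxan-3-yl, whereas the wider step, a number 1.40 log units lower from compound 1 to compound 3 (beyond the scatter), shows that the size of the fall from compound 1 also depends on which of the two oxane groups is attached. Nothing available here gives a reason for the difference between these two groups.

The compounds shown leave open whether other groups at this place would follow the same order, for example oxan-2-yl, or cyclohexyl and piperidin-4-yl, which would show what happens when the ring oxygen is replaced by a carbon or by an amine nitrogen. They also leave open whether the gap between oxan-3-yl and oxan-4-yl would recur on a different core.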